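The source may hold more compounds than are shown below. What is called first, only, known or untested is meant among the compounds shown, and "the series" means these compounds.

Measured in a functional assay for inhibition, with Homo sapiens as the target; a higher number here means a weaker inhibitor, a lower number a stronger inhibitor:
compound 1 `COc1ccc(Nc2nccc(-c3cccs3)n2)cc1` gives 3900 nM
compound 2 `COc1ccc(Nc2nccc(-c3cccnc3)n2)cc1` gives 1700 nM
compound 3 `COc1ccc(Nc2nccc(-c3ccncc3)n2)cc1` gives 4200 nM

Of these three numbers in this assay, compound 3 carries the highest, although compound 1 sits within the scatter of it: the step is a 1.1-fold higher number from compound 1 to compound 3 (0.03 log units; within the scatter). The gap to compound 2 is larger, a 2.5-fold higher number from compound 2 to compound 3 (0.39 log units; beyond the scatter), a modest step beyond the scatter. The remaining measured step, a 2.3-fold lower number from compound 1 to compound 2 (0.36 log units; beyond the scatter), is of similar size in the opposite sense.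

Compound 4 `Oc1ccc(Nc2nccc(-c3ccncc3)n2)cc1` differs from compound 3 in a single place: hydrogen in place of methyl on an oxygen on an aromatic ring. For the measured compounds named here, none of the measured steps bears on this change. Each of them swaps the ring attached to the shared core while the methoxy stays in place, so the three compounds give no guide to how a hydroxy compares with a methoxy at that position. With nothing to draw on, the expectation for compound 4 is a number close to that of compound 3, with no direction favoured and a step that may well fall within the scatter, though a modest shift either way cannot be ruled out. Compound 4 is therefore estimated at 4000 nM in this assay, within a range of 1300 nM to 12000 nM, the expected step being a 1.1-fold lower number from compound 3 to compound 4 (0.02 log units; within the scatter).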

Compound 4, half-maximal inhibitory concentration: 3300 nM
Compound 4: middle estimate off by 1.2-fold (0.08 log units), on the high side; the measured number falls inside the stated range.
By their numbers in this assay, from the lowest: compounds 2, 4, 1 and 3 (each within the scatter of the next, the first and the last beyond it).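

For the compounds shown here, compound 4 gives the first measured change at this oxygen rather than at the ring on the shared core, and in this assay it reads as follows: (a 1.3-fold lower number from compound 3 to compound 4 (0.10 log units; within the scatter)). The two compounds cannot be told apart there, so, for this one pair carrying pyridin-4-yl, methoxy and hydroxy on the aromatic ring are interchangeable as far as this read-out can show. Nothing shown offers a reason for this result.

The compounds shown leave open whether a larger group on that oxygen, such as an ethyl or a longer chain, or an amine in place of the oxygen, would stay as close to compound 3 as hydroxy does. Going by these compounds alone, they also leave open whether methoxy to hydroxy would read the same with the pyridin-3-yl of compound 2 or the thiophen-2-yl of compound 1 on the shared core, since this change is seen only with pyridin-4-yl.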